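Fluoro in place of hydrogen on the benzyl group

A few compounds are considered here, and "the series" means these few. Any claim that something is new, unique, unknown or untested is made for them only; others in the source may bear on it.

Two compounds of the series carry measurements. Compound 1 `CCN1C(=O)S/C(=C\c2ccc(N)cc2)C1=O` is the smaller member; in a functional assay on CCRF-CEM cells (Homo sapiens) for cytotoxicity, read by cell counting, with a stated time of 3 days (a lower number here means a stronger inhibitor, a higher number a weaker inhibitor), compound 1 gives 91000 nM. Among the measured compounds shown here, compound 2 `C=C(Br)C(=O)Nc1ccc(/C=C2\SC(=O)N(Cc3ccccc3)C2=O)cc1` is the larger member; in this assay compound 2 gives 2300 nM, the lowest of the two numbers, with compound 1 as its only neighbour and that neighbour standing beyond the usual scatter. For the measured compounds named here, no measured pair differs in a single place, so no single structural step can be read from the numbers as they stand.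

Compound 3 `C=C(Br)C(=O)Nc1ccc(/C=C2\SC(=O)N(Cc3ccc(F)cc3)C2=O)cc1` has not been measured. It differs from compound 2 by fluoro in place of hydrogen on an aromatic carbon. Nothing measured in the series speaks to this change, so the expectation rests on the closeness of the two structures alone. The step from compound 2 to compound 3 is expected to be a 1.2-fold lower number from compound 2 to compound 3 (0.06 log units; within the scatter), no change beyond the scatter in either direction. Compound 3 is therefore estimated at 2000 nM in this assay, with a range from 700 nM to 6000 nM.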

Compound 3, half-maximal inhibitory concentration: 2400 nM
Estimate against measurement, compound 3: 1.2-fold (0.08 log units) below; low and high end bracket the measured number.
By their numbers in this assay, from the lowest: compounds 2 and 3 (each within the scatter of the next); then compound 1.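

In this assay, among the compounds shown here, the change reads a 1.0-fold higher number from compound 2 to compound 3 (0.02 log units; within the scatter) and is the first step that can be read at a single place, since compound 1 and compound 2 differ in more than one place. On the 4-fluorobenzyl group of compound 3, the aromatic carbon para to a large group therefore takes fluoro in place of hydrogen with no shift in the number beyond the scatter, so this one small substitution on the benzyl group leaves the cytotoxicity read-out where it stood. No measurement in hand bears on why the step is this small, so it stands as an observation only.

The compounds shown cover only hydrogen and fluoro at this position, so it remains open whether a larger or charged group there, such as methoxy, trifluoromethyl, an amine or a carboxylic acid, would move the number beyond the scatter. Also open, on these data alone, is how far the number depends on the benzyl group itself, and a single-place comparison with an ethyl group or a longer chain on the same core would address that.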